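The source may report more compounds than this note shows. Statements on the series, on what has been measured and on what is new or still open speak of the compounds shown alone.

Measured so far in a functional assay on brain (Rattus norvegicus, strain Wistar) for inhibition; a lower number here means a stronger inhibitor, a higher number a weaker inhibitor:
- compound 1 `Cc1[nH]c(=O)n(C2CCCCC2)c1-c1ccccc1`: 47600 nM
- compound 2 `Cc1ccc(-c2c(C)[nH]c(=O)n2C)cc1`: 85300 nM
- compound 3 `CCCc1ccc(-c2c(C)[nH]c(=O)n2C)cc1`: 21500 nM

Compound 3, at 21500 nM, has the lowest number of the three, which makes it the strongest inhibitor so far, and its gaps to compound 1 and compound 2 both exceed the usual scatter. All three remain weak in absolute terms.

The next structure, compound 4 `CCCCCOc1ccc(-c2c(C)[nH]c(=O)n2C)cc1`, keeps the core of compound 3 and alters one group: pentyloxy in place of propyl on an aromatic carbon. Put simply, this is pentyloxy in place of propyl on an aromatic carbon of a six-membered aromatic ring of carbon only.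

Among the measured compounds shown here, only one measured step bears on this change. It is a 4.0-fold lower number from compound 2 to compound 3 (0.60 log units; beyond the scatter), a modest gain from ethyl in place of hydrogen on a saturated chain carbon bound to an aromatic carbon. Compound 1 differs from the others in more than one place, so it offers no direct guide. For the measured compounds named here, no measured compound carries an oxygen in this group, and a single step is thin evidence, so the range must stay wide.

A further modest gain in this assay is expected, and the estimated change is a 2.4-fold lower number from compound 3 to compound 4 (0.38 log units; beyond the scatter). The estimate for compound 4 is 9000 nM, with an expected range of 2500 nM to 25000 nM.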

Compound 4, half-maximal inhibitory concentration: 4500 nM
The estimate for compound 4 lay 2.0-fold (0.30 log units) above the measured number; measured number inside the range.
By their numbers in this assay, from the lowest: compound 4; then compound 3; then compounds 1 and 2 (each within the scatter of the next).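

In this assay the aromatic carbon that held propyl accepts a clearly larger group with oxygen in it, and the number still falls: swapping propyl for pentyloxy gives a 4.8-fold lower number from compound 3 to compound 4 (0.68 log units; beyond the scatter) as a modest step. Set against the methyl group at the same carbon, pentyloxy gives a 19-fold lower number from compound 2 to compound 4 (1.28 log units; beyond the scatter) as a large step, so the number drops at each move along methyl, propyl and pentyloxy, and none of these three compounds goes against that order. The step to pentyloxy changes two things at once, the length of the group and the presence of an oxygen that counts as a hydrogen-bond acceptor, so it cannot show which of the two matters.

No measurement shown here offers an explanation for these gains. Still open, from the compounds shown here alone, is whether a plain hexyl chain, with carbon in place of the oxygen, would match pentyloxy, and whether a longer alkoxy chain, or a chain ending in an amine or a carboxylic acid, would bring the number down further or reverse the trend.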